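Swapping an amide substituent on a shared core

The source may report more compounds than this note shows. Statements on the series, on what has been measured and on what is new or still open speak of the compounds shown alone.

Of the compounds shown here, three built on one shared core have been measured in a functional assay on B16-F10 cells (Mus musculus) for antiproliferative activity, read by MTT assay, with a stated time of 48 h; a higher number here means a weaker inhibitor, a lower number a stronger inhibitor. Compound 1 `COc1ccc(-c2cn3cc(C4=CCN(S(=O)(=O)CCc5ccccc5)CC4)ccc3n2)cc1OC` gives 8080 nM, compound 2 `COc1ccc(-c2cn3cc(C4=CCN(C(=O)c5ccc(Cl)cc5)CC4)ccc3n2)cc1OC` gives 15300 nM, and compound 3 `COc1ccc(-c2cn3cc(C4=CCN(S(=O)(=O)C5CCCC5)CC4)ccc3n2)cc1OC` gives 7690 nM. Compound 2 carries the highest of the three numbers, but its gap to each neighbour is small: a 1.9-fold higher number from compound 1 to compound 2 (0.28 log units; within the scatter) and a 2.0-fold lower number from compound 2 to compound 3 (0.30 log units; within the scatter) both stay within the scatter, so the three compounds cannot be ranked against one another with confidence. The third measured step, a 1.1-fold lower number from compound 1 to compound 3 (0.02 log units; within the scatter), also stays within the scatter.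

Compound 4 `COc1ccc(-c2cn3cc(C4=CCN(C(=O)C5CC5)CC4)ccc3n2)cc1OC` differs from compound 2 at one place: cyclopropyl in place of 4-chlorophenyl on a carbonyl carbon. For the measured compounds named here, none of the measured steps changes only the group on the carbonyl carbon; the steps from compound 1 to compound 2 and from compound 2 to compound 3 exchange the whole group on the ring nitrogen, and the step from compound 1 to compound 3 exchanges a ring for a chain on a sulfonyl sulfur. All three of these changes left this assay essentially unmoved. On that basis compound 4 is expected to show no step beyond the scatter, a 1.3-fold lower number from compound 2 to compound 4 (0.11 log units; within the scatter). The estimate for compound 4 in this assay is 12000 nM, with a range from 5000 nM to 30000 nM.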

Compound 4, half-maximal inhibitory concentration: 19400 nM
For compound 4 the middle estimate is 1.6-fold (0.21 log units) below the measured one, and the stated range covers the measured number.
By their numbers in this assay, from the lowest: compounds 3, 1, 2 and 4 (each within the scatter of the next, the first and the last beyond it).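

For the compounds shown here, replacing 4-chlorophenyl with the much smaller cyclopropyl on a carbonyl carbon changes only that group, and it leaves this assay essentially unmoved, with a 1.3-fold higher number from compound 2 to compound 4 (0.10 log units; within the scatter); the aromatic ring can therefore give way to a small non-aromatic ring here without a readable change in this assay. Going by these compounds alone, compound 4 also supplies the first steps that lie beyond the scatter, a 2.5-fold higher number from compound 3 to compound 4 (0.40 log units; beyond the scatter) and a 2.4-fold higher number from compound 1 to compound 4 (0.38 log units; beyond the scatter), both modest and both exchanging a sulfonyl group for cyclopropylcarbonyl on an amine nitrogen in a ring, although compound 2 goes against any general sulfonyl-to-carbonyl trend, as its own steps to compound 1 and compound 3 stay within the scatter. Nothing available here explains either result.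

The compounds shown leave open whether an amine or a carboxylic acid on the carbonyl carbon, or a longer carbon chain in place of cyclopropyl, would move the number beyond the scatter. They also leave open whether a plain phenyl or a cyclopentyl on the carbonyl carbon would behave like the two groups tested there.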